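This account rests on a few compounds, and the source may have more. Where it says the series, first, only, none or still open, it means among the compounds named here.

Compound 1, with the structure `COc1ccc(Cl)cc1C(=O)Nc1ccc(C2=NN(C)C(c3ccccc3[N+](=O)[O-])C2)cc1`, compound 2, with the structure `COc1ccc(C2CC(c3ccc(NC(=O)c4cc(Cl)ccc4OC)cc3)=NN2c2ccccc2)cc1`, and compound 3, with the structure `COc1ccc(Cl)cc1C(=O)Nc1ccc(C2=NN(c3ccccc3)C(c3ccccc3[N+](=O)[O-])C2)cc1`, share one core and differ only in the groups hung on the five-membered non-aromatic ring with 2 nitrogen. In a functional assay on the whole organism (plasma, strain albino) for inhibition, with Rattus norvegicus as the target, with stated times of 1 h and 4 h, at a dose of 25 mg/kg by the oral route (a higher number here means a stronger effect of the compound at the dose given, a lower number a weaker effect), compound 1 gives 83.8%, compound 2 gives 82.3% and compound 3 gives 73.3%. Compound 3 therefore has the lowest of the three numbers, though its gap to compound 2 lies within the scatter; only its gap to compound 1 lies beyond it. The two single-point changes measured so far are a number 9 percentage points lower from compound 2 to compound 3 (within the scatter) and a number 10.5 percentage points lower from compound 1 to compound 3 (beyond the scatter).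

Compound 4, with the structure `COc1ccc(Cl)cc1C(=O)Nc1ccc(C2=NNC(c3ccccc3[N+](=O)[O-])C2)cc1`, has not yet been measured in this assay. It differs from compound 3 in one place: hydrogen in place of phenyl on an amine nitrogen in a ring. Going by the values given here, the step that bears on this change is the one between compound 1 and compound 3, which touched the same ring nitrogen and gave a modest drop when phenyl replaced methyl. Among the compounds with values here, removing the phenyl again could be expected to recover part of that drop, but no measured step shows what a bare hydrogen does at this nitrogen, so the expectation is loose. Compound 4 is therefore expected to give about 80%, with a likely range from 65% to 92%. This estimate means a step of a number 6.7 percentage points higher from compound 3 to compound 4 (within the scatter), expected because a number 10.5 percentage points lower from compound 1 to compound 3 (beyond the scatter) was only modest.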

Compound 4, a percentage reported as inhibition, in the whole organism at one dose (the size of the read-out at that dose, not a potency): 72.3%
Beside the measured number, compound 4's estimate is 7.7 percentage points above it; low and high end bracket the measured number.
By their numbers in this assay, from the lowest: compounds 4, 3, 2 and 1 (each within the scatter of the next, the first and the last beyond it).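

Replacing phenyl with a bare hydrogen on this ring nitrogen gives a number 1 percentage points lower from compound 3 to compound 4 (within the scatter) in this assay, so taking away the whole phenyl ring changes the read-out by no more than the usual scatter. Methyl is the group that stands apart among the three at this position, since the step to hydrogen, a number 11.5 percentage points lower from compound 1 to compound 4 (beyond the scatter), is modest but lies beyond the scatter, as does the earlier step to phenyl, and this holds only for the three compounds that carry the 2-nitrophenyl group. No measurement shown here explains why this nitrogen responds in this way.

The compounds shown leave open whether the higher number belongs to methyl alone or would also appear with an ethyl group or a longer chain on this ring nitrogen. They also leave open whether the same order among methyl, phenyl and hydrogen would hold with 4-methoxyphenyl in place of 2-nitrophenyl on the saturated ring carbon, or at doses other than the single one used here.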